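This account rests on a few compounds, and the source may have more. Where it says the series, first, only, none or still open, it means among the compounds named here.

Compound 1 `Cc1nc2ccccc2n1C1CCN(CCCC(=O)c2ccc(F)cc2)CC1` — 0.85 mg/kg
Compound 2 `O=C(CCCSc1nc2ccccc2n1C1CCN(CCCC(=O)c2ccc(F)cc2)CC1)c1ccc(F)cc1` — 14 mg/kg

Of the compounds shown here, two have been measured in a functional assay on the whole organism (strain STD-ddY) for inhibition, with Mus musculus as the target, with a stated time of 5 min; on this read-out lower numbers stand for an effect already at smaller amounts and higher numbers for an effect only at larger amounts of compound. Compound 1 gives 0.85 mg/kg, and compound 2 gives 14 mg/kg. Compound 1 thus stands at the lowest of the two numbers, and the gap to compound 2 lies beyond the usual scatter of this assay. Both compounds share the same core and the same chain ending in a fluorophenyl ketone; they differ only in the group sitting on the core.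

Compound 3 `O=C(CCCN1CCC(n2c(Sc3ccccc3[N+](=O)[O-])nc3ccccc32)CC1)c1ccc(F)cc1` has not yet been measured. It differs from compound 1 in one place: (2-nitrophenyl)sulfanyl in place of methyl on an aromatic carbon. Going by the values given here, the change is a large one in size, and the only comparison available, compound 1 against compound 2, shows that a large sulfanyl group at this place went with a clearly higher number. On this basis compound 3 is expected to show a rise beyond the scatter in this assay, a step of a 5.9-fold higher number from compound 1 to compound 3 (0.77 log units; beyond the scatter). The estimated value for compound 3 is 5 mg/kg, within a range of 1.5 mg/kg to 20 mg/kg.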

Compound 3, dose for half-maximal effect: 11 mg/kg
Compound 3: middle estimate off by 2.2-fold (0.34 log units), on the low side; low and high end bracket the measured number.
By their numbers in this assay, from the lowest: compound 1; then compounds 3 and 2 (each within the scatter of the next).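

In this assay, placing (2-nitrophenyl)sulfanyl instead of methyl on the aromatic carbon between two ring nitrogen atoms gives a 13-fold higher number from compound 1 to compound 3 (1.11 log units; beyond the scatter), so compound 3 joins compound 2 as a second sulfur-linked example with a number well above that of compound 1. What the sulfur carries makes no readable difference among the two sulfur-linked compounds: 2-nitrophenyl in place of 3-((4-fluorophenyl)carbonyl)propyl on the sulfur gives a 1.3-fold lower number from compound 2 to compound 3 (0.10 log units; within the scatter), a step within the scatter, so an aromatic ring and a chain ending in a fluorophenyl ketone read alike here. No measurement is at hand that would explain why these groups behave as they do.

The compounds shown leave open whether the higher numbers go with the sulfur link itself or with the large groups attached to it, a question that a small methylsulfanyl group or a bare hydrogen at this place could address. They also leave open how a group linked through another atom, such as an amine or an ether oxygen carrying the same 2-nitrophenyl ring, would read in this assay.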